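This account rests on a few compounds, and the source may have more. Where it says the series, first, only, none or still open, it means among the compounds named here.

Compounds measured so far in this series:

Compound 1 `O=C(Nc1ccc(Cl)c(-c2nnc3c(Cl)cccn23)c1)c1ccccc1Cl`: in a functional assay on MCF7 cells (Homo sapiens) for antiproliferative activity, read by MTT assay, with a stated time of 72 h (on this read-out lower numbers stand for stronger inhibition and higher numbers for weaker inhibition), compound 1 gives 92200 nM.
Compound 2 `Cc1cc(Cl)ccc1C(=O)Nc1ccc(Cl)c(-c2nnc3c(Cl)cccn23)c1`: in this assay compound 2 gives only a limit, > 100000 nM.
Compound 3 `O=C(Nc1ccc(Cl)c(-c2nnc3c(Cl)cccn23)c1)c1ccccn1`: in this assay compound 3 gives 96400 nM.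

Compound 3 carries the highest of the two numbers, yet its nearest neighbour is compound 1, and the step of a 1.0-fold higher number from compound 1 to compound 3 (0.02 log units; within the scatter) lies within the scatter. The limit of compound 2 is described by the limit of > 100000 nM in this assay, at which 1 of the 3 values shown sits. Every measured step exchanges the aryl group on the carbonyl carbon: an at least 1.0-fold higher number from compound 1 to compound 2 (0.03 log units; that floor lies within the scatter) and an at least 1.0-fold lower number from compound 2 to compound 3 (0.01 log units; that floor lies within the scatter) are both no larger than the scatter, so the aryl on the carbonyl carbon has not moved the number in any direction beyond chance.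

Compound 4 `O=C(Nc1ccc(Cl)c(-c2nnc3c(Cl)cccn23)c1)c1cccnc1` is not yet measured. Its difference from compound 3 is pyridin-3-yl in place of pyridin-2-yl on a carbonyl carbon. This is a change of the same kind as the measured steps, and those steps were flat, so no shift beyond the scatter is expected in this assay. The step from compound 3 is accordingly expected to be a 1.0-fold lower number from compound 3 to compound 4 (0.01 log units; within the scatter). Compound 4 is estimated at 95000 nM, within 45000 nM to 200000 nM.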

Compound 4, half-maximal inhibitory concentration: > 100000 nM
Compound 4 ended at the assay's limit; the forecaster's own chance of this, stated with the estimate: 40%; middle value at least 1.0-fold (0.02 log units) away from the limit.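

In this assay, an exchange that keeps the same atoms and only joins them differently, pyridin-3-yl in place of pyridin-2-yl on a carbonyl carbon, gives an at least 1.0-fold higher number from compound 3 to compound 4 (0.01 log units; that floor lies within the scatter), so this placement of the ring nitrogen adds no readable shift, and the exchange against 2-chlorophenyl gives an at least 1.0-fold higher number from compound 1 to compound 4 (0.03 log units; that floor lies within the scatter). Compound 4 gives only a limit, > 100000 nM. The limit now takes in more of the series, so the aryl exchanges shown are increasingly bounded by it rather than sized: the limit of > 100000 nM in this assay, at which 2 of the 4 values shown sit.

The step between compound 2 and compound 4 cannot be read, since both values are limits. Still open, on these data alone, is whether anything other than an aryl on the carbonyl carbon, such as an aliphatic amine or a carboxylic acid-bearing chain, moves the number beyond the scatter.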